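Dimethylamino in Place of Methoxy on the Phenoxy Ring

A few compounds are considered here, and "the series" means these few. Any claim that something is new, unique, unknown or untested is made for them only; others in the source may bear on it.

Compound 1 `CC(C)(C)c1ccc(Oc2ccc3c(NCCCNCc4ccco4)ccnc3c2)cc1`: 3100 nM
Compound 2 `COc1cccc(Oc2ccc3c(NCCCNCc4ccco4)ccnc3c2)c1`: 15500 nM

Among the measured compounds shown here, in an ADME assay on HepG2 cells (Homo sapiens) for cytotoxicity, read by luminescence, CellTiter-Glo and ATP content, with a stated time of 72 h (a higher number here means that more compound is needed for the effect, a lower number that less compound is needed), compound 2 gives 15500 nM, the highest of the two numbers; the only other number comes from compound 1, and the gap is a 5.0-fold higher number from compound 1 to compound 2 (0.70 log units; beyond the scatter), beyond the scatter. Compound 3 `CN(C)c1cccc(Oc2ccc3c(NCCCNCc4ccco4)ccnc3c2)c1` differs from compound 2 by dimethylamino in place of methoxy on an aromatic carbon. For the measured compounds named here, no measured step tests this exchange: the one step known concerns a different group, so it does not bear on it. Compound 3 is therefore expected to land near compound 2, with an estimated step of a 1.3-fold lower number from compound 2 to compound 3 (0.11 log units; within the scatter), within the scatter. The estimate for compound 3 is 12000 nM, ranging from 4000 nM to 40000 nM.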

Compound 3, half-maximal effective concentration: 16000 nM
The estimate for compound 3 lay 1.3-fold (0.12 log units) below the measured number, within the range that was stated.
By their numbers in this assay, from the lowest: compound 1; then compounds 2 and 3 (each within the scatter of the next).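

In this assay, the exchange of 3-methoxyphenoxy for 3-(dimethylamino)phenoxy comes to a 1.0-fold higher number from compound 2 to compound 3 (0.01 log units; within the scatter) and so does not separate the two groups at this position. Compared with the 4-(tert-butyl)phenyl of compound 1, dimethylamino gives a 5.2-fold higher number from compound 1 to compound 3 (0.71 log units; beyond the scatter) in the same assay, so the gap already seen with methoxy also holds with this group. No evidence is available to explain this result.

Going by these compounds, whether a primary amine or a carboxylic acid at this position would also match methoxy remains open, as does the outcome with a longer alkoxy chain such as ethoxy or propoxy.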